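Going from methyl to ethyl on the shared core

The source may report more compounds than this note shows. Statements on the series, on what has been measured and on what is new or still open speak of the compounds shown alone.

Measured so far:
Compound 1 `CC(C)(C)c1cc(N)c2cc(NC(=O)/C=C/c3ccc(C(F)(F)F)cc3)ccc2n1`: 0.3 nM
Compound 2 `Cc1cc(N)c2cc(NC(=O)/C=C/c3ccc(C(F)(F)F)cc3)ccc2n1`: 8 nM

Within the data shown here, in an assay on isolated protein for displacement of a labelled ligand from melanin-concentrating hormone receptor 1 (Homo sapiens) (on this read-out lower numbers stand for stronger inhibition and higher numbers for weaker inhibition), compound 2 gives the highest of the two numbers; its only neighbour is compound 1, with a 27-fold higher number from compound 1 to compound 2 (1.43 log units; beyond the scatter). Compound 3 `CCc1cc(N)c2cc(NC(=O)/C=C/c3ccc(C(F)(F)F)cc3)ccc2n1` differs from compound 2 by methyl in place of hydrogen on a saturated chain carbon bound to an aromatic carbon; seen one bond further out, this reads methyl to ethyl. Among the measured compounds shown here, the single step that bears on it is the large rise when tert-butyl became methyl, so adding a carbon back is expected to move the number part of the way down again, as a 3.2-fold lower number from compound 2 to compound 3 (0.51 log units; beyond the scatter). Compound 3 is therefore estimated at 2.5 nM, with a range from 0.8 nM to 8 nM.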

Compound 3, half-maximal inhibitory concentration: 1.2 nM
For compound 3 the middle estimate is 2.1-fold (0.32 log units) above the measured one, and the stated range covers the measured number.
By their numbers in this assay, from the lowest: compound 1; then compound 3; then compound 2.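

In this assay, a single added carbon on the saturated chain already gives a 6.7-fold lower number from compound 2 to compound 3 (0.82 log units; beyond the scatter), so this position responds to a change much smaller than the earlier swap of tert-butyl for methyl. Ethyl recovers only part of that loss, leaving a 4.0-fold higher number from compound 1 to compound 3 (0.60 log units; beyond the scatter), and the numbers fall in step from methyl through ethyl to tert-butyl, with no compound shown going against that order. Nothing measured here explains this order.

From the compounds shown here alone, whether carbon count or branching matters more stays open, and a straight propyl chain or isopropyl would bear on that. How an amine at this position would behave is also unknown.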